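Removing the amino acid from a terpenoid quinone

The source may report more compounds than this note shows. Statements on the series, on what has been measured and on what is new or still open speak of the compounds shown alone.

Compound 1, `CC1=CCC[C@H]2[C@](C)(CC3=CC(=O)C=C(N[C@@H](CC(C)C)C(=O)O)C3=O)[C@@H](C)CC[C@]12C`, was tested in an ADME assay on MRC5 cells (Homo sapiens) for cytotoxicity, read by MTT assay, with a stated time of 72 h (on this read-out lower numbers stand for stronger inhibition and higher numbers for weaker inhibition), where it gives 73400 nM. Going by the values given here, this is the only number recorded in this assay in this group; the other two entries are limits. Compound 2, `CC(C)[C@@H](NC1=CC(=O)C=C(C(C)(C)C)C1=O)C(=O)O`, reaches only a limit of the assay, > 200000 nM. Compound 3, `CC(C)C[C@H](NC1=CC(=O)C=C(C(C)(C)C)C1=O)C(=O)O`, likewise reaches only a limit, > 200000 nM. So compound 1 stands as the sole measured value, set against (the limit of > 200000 nM in this assay, at which 2 of the 3 values shown sit).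

Compound 4, `CC1=CCC[C@H]2[C@](C)(CC3=CC(=O)C=CC3=O)[C@@H](C)CC[C@]12C`, differs from compound 1 in one place: hydrogen in place of (1-carboxy-3-methylbutyl)amino on a double-bonded ring carbon. The (1-carboxy-3-methylbutyl)amino group leaves and a hydrogen atom takes its place on a double-bonded ring carbon of the six-membered non-aromatic ring of carbon only.

Among the compounds with values here, no step between two measured compounds is available to set the size of this change. The account expects a moderate shift in this assay toward stronger inhibition, that is, a step of a 2.4-fold lower number from compound 1 to compound 4 (0.39 log units; beyond the scatter) going beyond the usual scatter but not by a large margin. Compound 4 is therefore estimated at 30000 nM, within a range from 8000 nM to 120000 nM.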

Compound 4, half-maximal inhibitory concentration: > 200000 nM
Compound 4: only a limit was reported; the forecaster's own chance of this, stated with the estimate: 15%; middle value at least 6.6-fold (0.82 log units) from the limit.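

In this assay, going by these compounds alone, putting hydrogen in place of (1-carboxy-3-methylbutyl)amino on this double-bonded ring carbon gives an at least 2.7-fold higher number from compound 1 to compound 4 (0.43 log units; beyond the scatter), the first step in this group that can be read at this position. The direction is now fixed: the core of compound 1 without this group does not reach a measured number, and compound 1 keeps the only one in the set. Compound 4 now stands with the other entries at a limit: the limit of > 200000 nM in this assay, at which 3 of the 4 values shown sit.

The compounds shown leave open which part of the leaving group goes with the lower number, since a plain amine or a carboxylic acid on a carbon chain at this ring carbon would separate the nitrogen from the acid. As far as these compounds go, how large the step really is also stays open, as compound 4 gives only a limit.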